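Trimming the oxetane side chain on a kinase inhibitor

A few compounds are considered here, and "the series" means these few. Any claim that something is new, unique, unknown or untested is made for them only; others in the source may bear on it.

Of the compounds shown here, three built on one shared core have been tested in an assay on isolated protein for inhibition of Leucine-rich repeat serine/threonine-protein kinase 2 (Homo sapiens), read by TR-FRET and LanthaScreen, with stated times of 50 min and 30 min, in the presence of a further agent that is not named here; on this read-out lower numbers stand for stronger inhibition and higher numbers for weaker inhibition. Compound 1 `Cc1nn(C2COC2)cc1Nc1nc(N)c2c(C#N)c(N3CCC[C@H]3C)n(C)c2n1` gives 38 nM, compound 2 `Cc1c(Nc2nc(N)c3c(C#N)c(N4CCC[C@H]4C)n(C)c3n2)cnn1[C@H]1CCOC1` gives 23 nM and compound 3 `Cc1c(Nc2nc(N)c3c(C#N)c(N4CCC[C@H]4C)n(C)c3n2)cnn1CC1(O)COC1` gives 16 nM. Compound 3 thus sits at the low end, with compound 2 within the scatter of it and compound 1 beyond it. For the measured compounds named here, the one measured step, a 1.4-fold lower number from compound 2 to compound 3 (0.16 log units; within the scatter), is small. Compound 4 `Cc1c(Nc2nc(N)c3c(C#N)c(N4CCC[C@H]4C)n(C)c3n2)cnn1C1COC1` differs from compound 3 by oxetan-3-yl in place of (3-hydroxyoxetan-3-yl)methyl on an aromatic nitrogen. Going by the values given here, no measured step covers this exchange; compound 1 also carries an oxetan-3-yl group on an aromatic nitrogen but differs from compound 4 elsewhere, and its number and that of compound 3 lie beyond the scatter apart. Compound 4 is therefore expected to give about 25 nM, between 10 nM and 60 nM, an expected step of a 1.6-fold higher number from compound 3 to compound 4 (0.19 log units; within the scatter) in this assay.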

Compound 4, half-maximal inhibitory concentration: 47 nM
The estimate for compound 4 lay 1.9-fold (0.27 log units) below the measured number; measured number inside the range.
By their numbers in this assay, from the lowest: compounds 3, 2, 1 and 4 (each within the scatter of the next, the first and the last beyond it).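

On the aromatic nitrogen the side chain does matter: in this assay, oxetan-3-yl in place of (3-hydroxyoxetan-3-yl)methyl gives a 2.9-fold higher number from compound 3 to compound 4 (0.47 log units; beyond the scatter), and in place of oxolan-3-yl it gives a 2.0-fold higher number from compound 2 to compound 4 (0.31 log units; beyond the scatter). With oxetan-3-yl on that nitrogen, 5-methyl-1-(oxetan-3-yl)-1H-pyrazol-4-yl and 3-methyl-1-(oxetan-3-yl)-1H-pyrazol-4-yl cannot be told apart, with a 1.2-fold higher number from compound 1 to compound 4 (0.09 log units; within the scatter). Nothing available explains these steps. The exchange between compound 3 and compound 4 alters the hydroxy group and the linking carbon together, leaving their separate shares open. On these data alone, how an amine or a carboxylic acid on this nitrogen would read is also open.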